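Dropping the Fluorine and Methoxy from the Benzyl Ring

This account rests on a few compounds, and the source may have more. Where it says the series, first, only, none or still open, it means among the compounds named here.

Compound 1 `COc1cc(N(Cc2ccccc2)C(=O)CSc2nc3ccccc3s2)cc(OC)c1OC` gives 44300 nM in a functional assay on MGC-803 cells (Homo sapiens) for antiproliferative activity, read by MTT assay, with a stated time of 48 h; a lower number here means a stronger inhibitor, a higher number a weaker inhibitor.
Compound 2 `COc1ccc2nc(SCC(=O)N(Cc3ccc(OC)c(O)c3)c3cc(OC)c(OC)c(OC)c3)sc2c1` gives 71 nM in this assay.
Compound 3 `COc1ccc(CN(C(=O)CSc2nc3ccccc3s2)c2cc(OC)c(OC)c(OC)c2)cc1F` gives 416 nM in this assay.

All three share the same core, differing only in the group carried on the saturated chain carbon bound to the amide-type nitrogen. Compound 3 stands second among the three numbers: compound 2 lies well beyond the scatter on the lower side, and compound 1 far beyond it on the higher side.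

Compound 4 `COc1cc(N(Cc2ccc(C)cc2)C(=O)CSc2nc3ccccc3s2)cc(OC)c1OC` has not yet been measured in this assay. Its difference from compound 3 is 4-methylphenyl in place of 3-fluoro-4-methoxyphenyl on a saturated chain carbon bound to an amide-type nitrogen. Among the measured compounds shown here, only one measured step bears on this change: a 110-fold lower number from compound 1 to compound 3 (2.03 log units; beyond the scatter), which shows that dressing the bare phenyl with the 3-fluoro-4-methoxy pattern lowered the number greatly. Compound 4 gives up that pattern and keeps only a single methyl, so it sits structurally between compound 1 and compound 3, and a clearly higher number than compound 3 is expected, though probably not as high as that of compound 1, because the step of a 110-fold lower number from compound 1 to compound 3 (2.03 log units; beyond the scatter) may rest partly on simply carrying any substituent. The expected step is a 12-fold higher number from compound 3 to compound 4 (1.08 log units; beyond the scatter). Compound 4 is therefore estimated at 5000 nM, within a range from 1000 nM to 25000 nM.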

Compound 4, half-maximal inhibitory concentration: 54200 nM
The estimate for compound 4 lay 11-fold (1.04 log units) below the measured number, outside the stated range (above it).
By their numbers in this assay, from the lowest: compound 2; then compound 3; then compounds 1 and 4 (each within the scatter of the next).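

In this assay, placing 4-methylphenyl on the saturated chain carbon bound to the amide-type nitrogen gives a 130-fold higher number from compound 3 to compound 4 (2.11 log units; beyond the scatter) and so removes nearly all of what the 3-fluoro-4-methoxyphenyl group offers at this position. Methyl in place of hydrogen on the bare phenyl ring gives a 1.2-fold higher number from compound 1 to compound 4 (0.09 log units; within the scatter) and so makes no readable difference, which means that among these compounds, simply carrying a substituent on this ring is not enough to give the low number seen with compound 3. The position is therefore sensitive to which group it carries, but no measurement here explains why the 3-fluoro-4-methoxyphenyl group stands apart from 4-methylphenyl.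

Whether the fluorine, the methoxy or the two together account for the difference stays open, and a 4-methoxyphenyl or a 3-fluorophenyl group at the same place would begin to separate them. As far as these compounds go, it is also open whether another group in place of the methyl, such as an amine or a chlorine, would behave like the methyl or like the 3-fluoro-4-methoxy pattern.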